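Removing a Methyl Group from a Pyridine Thiosemicarbazide

This account rests on a few compounds, and the source may have more. Where it says the series, first, only, none or still open, it means among the compounds named here.

Measured compounds:
Compound 1, `Cc1ccnc(/C(N)=N/NC(=S)N2CCCCCC2)c1`: 800 nM
Compound 2, `N/C(=N\NC(=S)N1CCN(c2ccccn2)CC1)c1ccc(F)cn1`: 1400 nM
Compound 3, `Cc1ccnc(/C(N)=N/NC(=S)N2CCCCC2)c1`: 1900 nM

Of the compounds shown here, three sharing a thiosemicarbazide core have been tested in a functional assay on A-375 cells (Homo sapiens) for cytotoxicity, read by MTT assay, with a stated time of 72 h; on this read-out higher numbers stand for weaker inhibition and lower numbers for stronger inhibition. Compound 1 gives 800 nM, the lowest of the three numbers. Compound 2 gives 1400 nM, which lies within the scatter of compound 1, so no order between those two can be claimed. Compound 3 gives 1900 nM, and the gap from compound 1 to compound 3 is beyond the scatter.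

Compound 4, `N/C(=N\NC(=S)N1CCCCCC1)c1ccccn1`, is not yet measured. It differs from compound 1 in one place: hydrogen in place of methyl on an aromatic carbon. Going by the values given here, no pair of measured compounds shows this change, so its effect is open. A small step is expected in this assay, if anything toward a slightly higher number, but likely no more than the scatter. Compound 4 is therefore estimated at 1000 nM, with a range from 400 nM to 2500 nM. The expected step of a 1.3-fold higher number from compound 1 to compound 4 (0.10 log units; within the scatter) is small.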

Compound 4, half-maximal inhibitory concentration: 740 nM
For compound 4 the middle estimate is 1.4-fold (0.13 log units) above the measured one, within the range that was stated.
By their numbers in this assay, from the lowest: compounds 4, 1, 2 and 3 (each within the scatter of the next, the first and the last beyond it).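

Going by these compounds alone, until now, no measured pair showed what happens when this methyl group is removed. In this assay, hydrogen in place of methyl on this aromatic carbon gives a 1.1-fold lower number from compound 1 to compound 4 (0.03 log units; within the scatter), so no difference between the two can be claimed, and in this pair the methyl group is not needed to keep the number in this range. No supporting data are available to explain this result, which therefore stands as a plain observation.

Still open, from the compounds shown here alone, is whether a larger group on this same aromatic carbon, such as ethyl, methoxy or an amine, would shift the number beyond the scatter. Also open, going by these compounds, is whether the same swap of methyl for hydrogen would leave the number just as unmoved on compound 3.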